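Adding a Second Chloro to a Weakly Cytotoxic Amide

The compounds below may be only part of what the source reports. "The series", "measured", "known", "first", "only" and "open" are said of these compounds alone.

For the measured compounds named here, compound 1, `Cc1cc(S(N)(=O)=O)ccc1NC(=O)COc1ccc(Cl)cc1NC(=O)c1cccc(Cl)c1`, was tested in a functional assay on C8166 cells (Homo sapiens) for cytotoxicity, read by MTT assay (on this read-out lower numbers stand for higher toxicity in this test and higher numbers for lower toxicity in this test), and gives 59700 nM, the highest of the three numbers measured so far. Its two companions change only the aryl group attached to the carbonyl carbon. Compound 2, `Cc1cc(S(N)(=O)=O)ccc1NC(=O)COc1ccc(Cl)cc1NC(=O)c1ccccc1[N+](=O)[O-]`, gives 54800 nM, and compound 3, `Cc1cc(C)cc(C(=O)Nc2cc(Cl)ccc2OCC(=O)Nc2ccc(S(N)(=O)=O)cc2C)c1`, gives 36500 nM. The step of a 1.1-fold lower number from compound 1 to compound 2 (0.04 log units; within the scatter) and the step of a 1.6-fold lower number from compound 1 to compound 3 (0.21 log units; within the scatter) both stay within the scatter, as does a 1.5-fold lower number from compound 2 to compound 3 (0.18 log units; within the scatter).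

Compound 4, `Cc1cc(S(N)(=O)=O)ccc1NC(=O)COc1ccc(Cl)cc1NC(=O)c1cc(Cl)ccc1Cl`, differs from compound 1 as follows: chloro in place of hydrogen on an aromatic carbon. Going by the values given here, no measured pair adds a chloro to this ring, so no step speaks to the change directly; what the three measured compounds show is that exchanging one aryl group for another on this carbonyl carbon has left the read-out unchanged within the scatter. The expected step is therefore a 1.2-fold lower number from compound 1 to compound 4 (0.08 log units; within the scatter), no more than the scatter allows. Compound 4 is expected to give 50000 nM, with a range from 25000 nM to 100000 nM.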

Compound 4, half-maximal cytotoxic concentration: 42100 nM
The estimate for compound 4 lay 1.2-fold (0.07 log units) above the measured number; measured number inside the range.
By their numbers in this assay, from the lowest: compounds 3, 4, 2 and 1 (each within the scatter of the next).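

Adding a chloro on an aromatic carbon, ortho to a large group and para to a chloro group, gives in this assay a 1.4-fold lower number from compound 1 to compound 4 (0.15 log units; within the scatter) and so stays within the scatter. The 2,5-dichlorophenyl group also matches the other aryl groups within the scatter, with a 1.2-fold higher number from compound 3 to compound 4 (0.06 log units; within the scatter) and with a 1.3-fold lower number from compound 2 to compound 4 (0.11 log units; within the scatter) as the remaining steps, so all four aryl groups now read alike in this test. No measurement shown here gives a reason for this result.

From the compounds shown here alone, whether an amine, a carboxylic acid or a longer chain on this ring would move the number beyond the scatter remains open. The compounds shown also leave open what a change elsewhere in the shared core would do, since all four differ only in this aryl group.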